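A few compounds are considered here, and "the series" means these few. Any claim that something is new, unique, unknown or untested is made for them only; others in the source may bear on it.

In a physicochemical assay for lipophilicity, read by HPLC (on this read-out lower numbers stand for lower lipophilicity and higher numbers for higher lipophilicity), compound 1 `O=C1/C(=C\c2ccccc2)C(c2ccccc2)Oc2ccccc21` gives 3.9, compound 2 `Cc1ccc(/C=C2\C(=O)c3ccccc3OC2c2ccccc2)cc1` gives 4.39 and compound 3 `O=C1/C(=C/c2ccc(Br)cc2)C(c2ccccc2)Oc2ccccc21` gives 4.46. Compound 3 thus stands level with compound 2 within the scatter, and beyond the scatter above compound 1. Compound 4 `O=C1/C(=C\c2ccc(Br)cc2)C(c2ccccc2)Oc2ccccc21` is the next to be read, and the change is this: the two compounds have the same atoms and bonds; at least one stereo element is drawn with a configuration in one of them and without one in the other: 1 of 2 stereo elements differ; a double bond is drawn E in compound 3 and Z in compound 4. Among the compounds with values here, the only measured step, a number 0.49 log units higher from compound 1 to compound 2 (beyond the scatter), is methyl in place of hydrogen on an aromatic carbon, so it says nothing direct about a double bond drawn E or Z. No measured pair shows such a change. The expected step, a number 0.06 log units lower from compound 3 to compound 4 (within the scatter), therefore stays within the scatter. For compound 4 the estimated value is 4.4, with an expected range of 4 to 4.8.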

Compound 4, partition coefficient: 4.71
Compound 4: middle estimate off by 0.31 log units, on the low side; measured number inside the range.
By their numbers in this assay, from the lowest: compound 1; then compounds 2, 3 and 4 (each within the scatter of the next, the first and the last beyond it).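

In this assay the change of the double bond from E to Z gives a number 0.25 log units higher from compound 3 to compound 4 (within the scatter) so the two drawings of this double bond are not told apart at this position. Bromo in place of methyl on an aromatic carbon gives a number 0.32 log units higher from compound 2 to compound 4 (beyond the scatter) and the step from hydrogen to bromo gives a number 0.81 log units higher from compound 1 to compound 4 (beyond the scatter) with the double bond drawn alike in all three. The E and Z reading carries one reservation: the fact that one of compounds 3 and 4 is drawn with a defined configuration and the other without, at the place where they differ. The compounds shown leave open how an amine or a carboxylic acid would read in place of bromo, and whether E and Z also stay within the scatter of each other with methyl there.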